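Phenyl replaces 2-fluoro-3-(methoxycarbonyl)phenyl in compound 3

The compounds below may be only part of what the source reports. "The series", "measured", "known", "first", "only" and "open" are said of these compounds alone.

In an ADME assay on a cell-free system (plasma, Homo sapiens) for metabolic stability, read by LC-MS (on this read-out lower numbers stand for a shorter-lived compound and higher numbers for a longer-lived compound), compound 1 (`NCc1ccc(C(=O)Nc2ccncc2F)cc1-c1cccc(C(=O)OCC2CCCO2)c1`) gives < 0.0834 h as a limit. Compound 2 (`COC(=O)c1cccc(NC(=O)c2cccc(-c3cc(C(=O)Nc4ccncc4F)ccc3CN)c2)c1F`) gives < 0.0834 h as a limit too. Within the data shown here, the one measured step is a step that the two limits leave unreadable from compound 1 to compound 2 and offers no size to carry over (the limit of < 0.0834 h in this assay, at which 2 of the 2 values shown sit). Compound 3 (`NCc1ccc(C(=O)Nc2ccncc2F)cc1-c1cccc(C(=O)Nc2ccccc2)c1`) has phenyl in place of 2-fluoro-3-(methoxycarbonyl)phenyl on an amide-type nitrogen. Among the measured compounds shown here, compound 2, a limit at < 0.0834 h in this assay here, holds the methoxycarbonyl that leaves, so a longer half-life is expected, though no measured step sets its size. The expected change is an at least 71-fold higher number from compound 2 to compound 3 (1.85 log units; beyond the scatter) on this estimate. For compound 3 the expected half-life is 6 h (1 h to 24 h).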

Compound 3, half-life: > 2 h
Compound 3: no number, only a limit; the forecaster's own chance of this, stated with the estimate: 35%; the middle value does not contradict the limit.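

In this assay compound 3 gives > 2 h, which is a limit. Phenyl in place of 2-fluoro-3-(methoxycarbonyl)phenyl on an amide-type nitrogen gives the first readable step in the series, an at least 23-fold higher number from compound 2 to compound 3 (1.37 log units; beyond the scatter), while anilino in place of (oxolan-2-yl)methoxy on a carbonyl carbon gives an at least 23-fold higher number from compound 1 to compound 3 (1.37 log units; beyond the scatter). Limits stand at both ends of each step, and the step between the two earlier compounds cannot be read.

On these data alone, the fluorine and the methoxycarbonyl leave together, so the share of each remains open. Also open, as far as these compounds go, is whether a phenyl carrying a carboxylic acid or an amine would keep the half-life of compound 3.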